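The source may report more compounds than this note shows. Statements on the series, on what has been measured and on what is new or still open speak of the compounds shown alone.

Measured in a functional assay on U-373MG ATCC cells (Homo sapiens) for cytotoxicity, read by MTT assay, with a stated time of 72 h; on this read-out lower numbers stand for stronger inhibition and higher numbers for weaker inhibition:
- compound 1 `CSc1nc(Cl)c(C(=O)c2ccccc2)s1`: > 100000 nM, a limit
- compound 2 `CSc1nc(Br)c(C(=O)c2ccccc2)s1`: 89000 nM
- compound 3 `N#Cc1sc(N2CCCC2)nc1Cl`: > 100000 nM, a limit

Among the measured compounds shown here, compound 2 is the only compound here with an actual number, 89000 nM. Compound 1 and compound 3 both stand at the limit of > 100000 nM in this assay, at which 2 of the 3 values shown sit.

The next compound is compound 4 `O=C(c1ccccc1)c1sc(N2CCCCC2)nc1Br`, which follows from compound 2 by a single change: piperidin-1-yl in place of methylsulfanyl on an aromatic carbon. In words, this is piperidin-1-yl in place of methylsulfanyl on an aromatic carbon, next to the ring nitrogen and next to the ring sulfur. The bromo group and the group of 8 heavy atoms stay as they are.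

For the measured compounds named here, the only measured step is an at least 1.1-fold lower number from compound 1 to compound 2 (0.05 log units; that floor lies within the scatter). It concerns bromo in place of chloro, not the methylsulfanyl group, and therefore gives no size for the present change. Going by the values given here, no measured step replaces methylsulfanyl.

Among the compounds with values here, with so little to go on, no step clearly beyond the scatter is expected in this assay, only a slight lean towards a lower number. A reading at the limit of the assay also remains possible. The expected step is a 1.8-fold lower number from compound 2 to compound 4 (0.25 log units; within the scatter). For compound 4 the expected value is 50000 nM. The estimated range for compound 4 runs from 15000 nM to 100000 nM.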

Compound 4, half-maximal inhibitory concentration: 78000 nM
For compound 4 the middle estimate is 1.6-fold (0.19 log units) below the measured one, within the range that was stated.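

Among the compounds shown here, the first measured step at this position, on an aromatic carbon next to the ring nitrogen and next to the ring sulfur, is a 1.1-fold lower number from compound 2 to compound 4 (0.06 log units; within the scatter), read in this assay for piperidin-1-yl in place of methylsulfanyl. The position therefore accepts a group of 6 heavy atoms with one six-membered non-aromatic ring in place of a group of 2 heavy atoms, and the values of the two compounds lie within the scatter of each other. Compound 4 gives an actual number and not a limit, so the pair offers a second numerical reading in a set where limits remain common: the limit of > 100000 nM in this assay, at which 2 of the 4 values shown sit.

Going by these compounds, it remains open whether any group at this position can move the value beyond the scatter, for instance a primary amine, a carboxylic acid or a longer chain such as n-hexyl in place of piperidin-1-yl. On these data alone, it is also open whether piperidin-1-yl gives a similar result with chloro in place of bromo, or with a group other than the group of 8 heavy atoms kept in compound 2 and compound 4.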